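The source may report more compounds than this note shows. Statements on the series, on what has been measured and on what is new or still open speak of the compounds shown alone.

Compound 1 `O=C(O)c1ccc(CN2CCC[C@H](OCc3cc(Cl)cc(Cl)c3)[C@@H]2c2ccccc2)s1` is tested in an assay on isolated protein for activation of cGMP-dependent protein kinase 1 (Homo sapiens), read by ADP-Glo, with stated times of 120 min and 40 min (on this read-out lower numbers stand for an effect already at smaller amounts and higher numbers for an effect only at larger amounts of compound), where compound 1 gives 76000 nM. Among the numbers shown, compound 1 stands highest, with compound 3 `COc1cc(C(=O)O)ccc1CN1CCC[C@H](OCc2cc(Cl)cc(Cl)c2)[C@@H]1c1ccccc1` nearest: in this assay compound 3 gives 62000 nM, and the step of a 1.2-fold lower number from compound 1 to compound 3 (0.09 log units; within the scatter) stays within the scatter. Compound 2 `Clc1cc(Cl)cc(CO[C@H]2CCCN(Cc3ccccc3)[C@H]2c2ccccc2)c1` reaches only a limit of this assay, > 200000 nM. Going by the values given here, two steps bear on the change ahead. Dropping the carboxy-bearing group gives an at least 2.6-fold higher number from compound 1 to compound 2 (0.42 log units; beyond the scatter), and bringing a carboxy-bearing group back gives an at least 3.2-fold lower number from compound 2 to compound 3 (0.50 log units; beyond the scatter); both are given only as least sizes due to the limit of > 200000 nM in this assay, at which 1 of the 3 values shown sits. Compound 4 `Clc1cc(Cl)cc(CO[C@H]2CCCN(Cc3ncc[nH]3)[C@H]2c2ccccc2)c1` differs from compound 1 in one place: 1H-imidazol-2-yl in place of 5-carboxythiophen-2-yl on a saturated chain carbon bound to an amine nitrogen in a ring. Like compound 2, compound 4 carries no carboxy group, so a modest rise in the number is expected, and the estimated step is a 2.0-fold higher number from compound 1 to compound 4 (0.30 log units; within the scatter), resting on an at least 2.6-fold higher number from compound 1 to compound 2 (0.42 log units; beyond the scatter). For compound 4 the expected value in this assay is 150000 nM, within a range from 60000 nM to 400000 nM, with a real chance that only a limit is reported.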

Compound 4, half-maximal effective concentration: 47000 nM
Compound 4: the middle estimate sits 3.2-fold (0.50 log units) above what was measured; measured number below the stated range.
By their numbers in this assay, from the lowest: compounds 4, 3 and 1 (each within the scatter of the next). At a limit, above all of these: compound 2.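

At this place, on a saturated chain carbon bound to an amine nitrogen in a ring, a carboxy group turns out not to be needed in this assay: 1H-imidazol-2-yl carries none, yet the steps are a 1.6-fold lower number from compound 1 to compound 4 (0.21 log units; within the scatter) and a 1.3-fold lower number from compound 3 to compound 4 (0.12 log units; within the scatter). Compound 2 had suggested that losing the carboxy group costs activity, but compound 4 goes against that reading, with an at least 4.2-fold lower number from compound 2 to compound 4 (0.62 log units; beyond the scatter). Compound 2 stands at a limit, so this last step is only a least size: the limit of > 200000 nM in this assay, at which 1 of the 4 values shown sits.

Still open, on these data alone, is whether another ring carrying nitrogen, such as pyridin-2-yl, would match 1H-imidazol-2-yl here, or whether the hydrogen on the imidazole nitrogen matters, as 1-methylimidazol-2-yl could show. Also open, as far as these compounds go, is whether a carboxylic acid added to the imidazole ring would change the number.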